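This account rests on a few compounds, and the source may have more. Where it says the series, first, only, none or still open, it means among the compounds named here.

Working notes on the series.

Compound 1 `COc1ccc(C2=NN(C3=NC(=O)/C(=C4\C(=O)Nc5ccc(Br)cc54)S3)C(c3ccc(OC)cc3)C2)cc1` and compound 2 `COc1ccc(C2CC(c3ccc4ccccc4c3)=NN2C2=NC(=O)/C(=C3\C(=O)Nc4ccc(Br)cc43)S2)cc1` share one core; compound 3 `COc1ccc(C2=NN(C3=NC(=O)/C(=C4\C(=O)Nc5ccccc54)S3)C(c3ccc(Cl)cc3)C2)cc1` and compound 4 `O=C1N=C(N2N=C(c3ccc4ccccc4c3)CC2c2ccc(Cl)cc2)S/C1=C1/C(=O)Nc2ccccc21` share another, and the difference between the two cores is not broken down here. In a functional assay on cells (Leukemia cell, Homo sapiens) for cytotoxicity, read by sulforhodamine B assay, with a stated time of 48 h (a lower number here means a stronger inhibitor of growth, a higher number a weaker inhibitor of growth), compound 1 gives 280 nM, compound 2 gives 130 nM, and compound 3 gives 86600 nM. Within the first core, the change naphthalen-2-yl in place of 4-methoxyphenyl on a carbon with a double bond to nitrogen gave a 2.2-fold lower number from compound 1 to compound 2 (0.33 log units; beyond the scatter). The change naphthalen-2-yl in place of 4-methoxyphenyl on a carbon with a double bond to nitrogen is the same kind of change, with the ring atom bearing a 4-chlorophenyl group rather than a 4-methoxyphenyl group, on a core where compound 3 is far weaker than compound 1. Among the measured compounds shown here, for compound 4 a step of about a 2.2-fold lower number from compound 3 to compound 4 (0.34 log units; beyond the scatter) is expected in this assay, resting on the single observed step of a 2.2-fold lower number from compound 1 to compound 2 (0.33 log units; beyond the scatter). Compound 4 is thus estimated at 40000 nM, with an expected range from 10000 nM to 120000 nM.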

Compound 4, concentration for 50% growth inhibition: 19100 nM
Compound 4: middle estimate off by 2.1-fold (0.32 log units), on the high side, within the range that was stated.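

In this assay, naphthalen-2-yl in place of 4-methoxyphenyl on a carbon with a double bond to nitrogen gave a 4.5-fold lower number from compound 3 to compound 4 (0.66 log units; beyond the scatter). The change carries from one core to the other in direction and, within the scatter, in size: the same change on two cores in this assay, a 2.2-fold lower number (0.33 log units; beyond the scatter) from compound 1 to compound 2 and a 4.5-fold lower number (0.66 log units; beyond the scatter) from compound 3 to compound 4, 2.1-fold (0.32 log units) apart, within the scatter of two such steps

Among the compounds shown here, this rests on only two pairs, so it does not show that the step would hold on any other core, and it does not explain the large difference in values between the two cores.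

The compounds shown leave open how the bromine and the 4-chlorophenyl group each contribute to that difference when taken singly. Also open, on these data alone, is what an amine or a carboxylic acid would give in place of naphthalen-2-yl on that carbon.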